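Oxindole Anilines: Chain Extension on Trifluoromethyl Core

The source may hold more compounds than are shown below. What is called first, only, known or untested is meant among the compounds shown, and "the series" means these compounds.

Measured so far:
compound 1 `CCCCC1(O)C(=O)Nc2ccc(Nc3ccc(Cl)cc3)cc21`, 2800 nM
compound 2 `CCCCCC1(O)C(=O)Nc2ccc(Nc3ccc(Cl)cc3)cc21`, 1900 nM
compound 3 `CCCCC1(O)C(=O)Nc2ccc(Nc3ccc(C(F)(F)F)cc3)cc21`, 2300 nM

All three were run in a functional assay on A549 cells (Homo sapiens) for antiproliferative activity, read by MTT assay, with a stated time of 48 h; on this read-out higher numbers stand for weaker inhibition and lower numbers for stronger inhibition. Compound 1 to compound 2 is the change (methyl in place of hydrogen on a saturated chain carbon, four bonds along the chain from a saturated ring carbon), and the step was a 1.5-fold lower number from compound 1 to compound 2 (0.17 log units; within the scatter). Compound 1 to compound 3 is the change (trifluoromethyl in place of chloro on an aromatic carbon), with the step of a 1.2-fold lower number from compound 1 to compound 3 (0.09 log units; within the scatter). Compound 3 and compound 2 lie within the usual scatter of each other.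

Compound 4 `CCCCCC1(O)C(=O)Nc2ccc(Nc3ccc(C(F)(F)F)cc3)cc21` is not yet measured. It differs from compound 3 by methyl in place of hydrogen on a saturated chain carbon, four bonds along the chain from a saturated ring carbon, the same change as from compound 1 to compound 2. Its value in this assay is expected to follow that earlier step, so the estimated step is a 1.4-fold lower number from compound 3 to compound 4 (0.16 log units; within the scatter), resting on compound 1 to compound 2 giving a 1.5-fold lower number from compound 1 to compound 2 (0.17 log units; within the scatter). Compound 4 is therefore estimated at 1600 nM, with a range from 900 nM to 3000 nM.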

Compound 4, half-maximal inhibitory concentration: 2200 nM
Compound 4: middle estimate off by 1.4-fold (0.14 log units), on the low side, within the range that was stated.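

In this assay, methyl in place of hydrogen on the chain gives a 1.0-fold lower number from compound 3 to compound 4 (0.02 log units; within the scatter), and the two instances of this change agree as far as can be read: the same change on two cores in this assay, a 1.5-fold lower number (0.17 log units; within the scatter) from compound 1 to compound 2 and a 1.0-fold lower number (0.02 log units; within the scatter) from compound 3 to compound 4, 1.4-fold (0.15 log units) apart, within the scatter of two such steps. Trifluoromethyl in place of chloro gives a 1.2-fold higher number from compound 2 to compound 4 (0.06 log units; within the scatter), and this change also shows no difference between cores: the same change on two cores in this assay, a 1.2-fold lower number (0.09 log units; within the scatter) from compound 1 to compound 3 and a 1.2-fold higher number (0.06 log units; within the scatter) from compound 2 to compound 4, 1.4-fold (0.15 log units) apart, within the scatter of two such steps. All four steps lie within the scatter, so neither change shows any dependence on the core, but the data do not show that either change has a real effect that could carry from one core to another.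

Open, going by these compounds, is whether a longer chain, or an amine or a carboxylic acid in place of trifluoromethyl, would give a step beyond the scatter. Only such a step could test transfer between cores.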